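The compounds below may be only part of what the source reports. "The series", "measured", "known", "first", "only" and "open" are said of these compounds alone.

Four compounds share one core. Compound 1 `O=C(Nc1cc(C(F)(F)F)cc(C(F)(F)F)c1)C1CCc2ccccc2N1C(=O)c1ccccc1Cl` carries a 2-chlorophenyl on a carbonyl carbon whose other neighbours are an amide-type nitrogen in a ring, while compound 2 `CC(=O)N1c2ccccc2CCC1C(=O)Nc1cc(C(F)(F)F)cc(C(F)(F)F)c1` has a methyl at that place. In a functional assay on HCT-15 cells (Homo sapiens) for cytotoxicity, read by sulforhodamine B assay, with a stated time of 72 h (a lower number here means a stronger inhibitor of growth, a higher number a weaker inhibitor of growth), compound 1 gives 4050 nM. For compound 2 the this assay reports only a limit, > 70000 nM. The change 2-chlorophenyl in place of methyl on a carbonyl carbon thus made an at least 17-fold lower number from compound 2 to compound 1 (1.23 log units; beyond the scatter), and the size of that step rests on (the limit of > 70000 nM in this assay, at which 1 of the 3 values shown sits).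

Compound 3 `CC(=O)N1c2ccccc2CCC1C(=O)Nc1ccccc1C(F)(F)F` also gives only a limit in this assay, namely > 80000 nM. How the core of compound 3 differs from the core of compound 2 is not broken down here. Compound 4 `O=C(Nc1ccccc1C(F)(F)F)C1CCc2ccccc2N1C(=O)c1ccccc1Cl` arises from compound 3 by the same change, (2-chlorophenyl in place of methyl on a carbonyl carbon), at a place described in the same words.

Because compound 3 sits at the limit of > 80000 nM in this assay, at which 1 of the 3 values shown sits, the earlier step gives a direction but not a firm size for the new one. Compound 4 is expected to give 15000 nM, between 3000 nM and 80000 nM. That amounts to an expected step of an at least 5.3-fold lower number from compound 3 to compound 4 (0.72 log units; beyond the scatter).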

Compound 4, concentration for 50% growth inhibition: 4220 nM
Compound 4: the middle estimate sits 3.6-fold (0.55 log units) above what was measured, and the stated range covers the measured number.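

Putting 2-chlorophenyl in place of methyl on the carbonyl carbon again lowers the number in this assay, with an at least 18-fold lower number from compound 3 to compound 4 (1.27 log units; beyond the scatter), and the change points the same way on both cores shown. The two steps can be set side by side, but neither has a firm size, so agreement in direction is all they establish: the same change on two cores in this assay, an at least 17-fold lower number (1.23 log units; beyond the scatter) from compound 2 to compound 1 and an at least 18-fold lower number (1.27 log units; beyond the scatter) from compound 3 to compound 4; the limit leaves it open whether they differ. As far as these compounds go, the new step also starts from a limit rather than a measured number, so its true size stays unknown and could be larger than the figure printed: the limit of > 80000 nM in this assay, at which 1 of the 4 values shown sits.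

The compounds shown leave open how other groups would behave at this carbonyl carbon, for example a plain phenyl, a longer chain or an amine. They also leave open whether the change carries over to cores with something other than trifluoromethyl on the phenyl ring of the amide, such as a nitrile.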